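The source may hold more compounds than are shown below. What is called first, only, known or untested is meant among the compounds shown, and "the series" means these compounds.

Of the compounds shown here, three have so far been measured in a functional assay on SMMC-7721 cells (Homo sapiens) for inhibition, read by CCK-8 assay, with a stated time of 72 h, tested at 2 uM; a lower number here means less inhibition of growth, a higher number more inhibition of growth at the concentration tested. Compound 1 `Nc1ccccc1NC(=O)c1ccc(CSc2nccc(C(F)(F)F)n2)cc1` gives 66.1%. Compound 3 `Nc1ccccc1NC(=O)/C=C/c1ccc(CSc2ccc(C(F)(F)F)cn2)cc1` gives 12.1%. Compound 2 `Nc1ccccc1NC(=O)c1ccc(CSc2ccc(Br)cc2)cc1` gives 10%, the lowest of the three numbers: compound 3 lies within the scatter of it, while compound 1 stands beyond the scatter above it. Compound 4 `Nc1ccccc1NC(=O)c1ccc(CSc2ccc(F)cc2)cc1` has not yet been measured; it differs from compound 2 in one place (fluoro in place of bromo on an aromatic carbon). Among the measured compounds shown here, no step between two measured compounds covers fluoro in place of bromo on an aromatic carbon, so the numbers give no ground for a large change in either direction. The step of a number 2 percentage points higher from compound 2 to compound 4 (within the scatter) in this assay is therefore expected to be small, none beyond the scatter. Compound 4 is estimated at 12%, between 3% and 25%.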

Compound 4, percent growth inhibition at one concentration: 6.58%
Estimate against measurement, compound 4: 5.4 percentage points above; the range from low to high includes it.
By their numbers in this assay, from the lowest: compounds 4, 2 and 3 (each within the scatter of the next); then compound 1.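

In this assay, the change of bromo to fluoro on the aromatic carbon para to a large group gives a number 3.4 percentage points lower from compound 2 to compound 4 (within the scatter). This exchange of one halogen for another therefore makes no readable difference at this position, at the concentration tested. No measurement of any property of these groups bears on this result.

From the compounds shown here alone, it remains open whether an amine, a carboxylic acid or a longer chain at this place would move the number beyond the scatter. Going by these compounds, whether the same exchange would stay as small on another core also remains open.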